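The compounds below may be only part of what the source reports. "The series", "measured", "known", "first", "only" and "open" are said of these compounds alone.

Measured in a functional assay on LOX IMVI cells (Homo sapiens) for cytotoxicity, read by resazurin assay, with a stated time of 72 h; on this read-out higher numbers stand for weaker inhibition and lower numbers for stronger inhibition:
Compound 1 `COc1cc(/C=C/C(=O)OCCCCCCO[N+](=O)[O-])ccc1O`: > 50000 nM (a limit)
Compound 2 `O=C(/C=C/c1ccc(OCCCCCCO[N+](=O)[O-])c(O)c1)OCCCCCCO[N+](=O)[O-]`: > 50000 nM (a limit)

Compound 2 has no numerical value: its > 50000 nM is a limit of the assay. Going by the values given here, the same holds across the series so far, with the limit of > 50000 nM in this assay, at which 2 of the 2 values shown sit. Compound 3 `COc1cc(/C=C/C(=O)OCCCCCCO[N+](=O)[O-])ccc1OCCCCCCO[N+](=O)[O-]` carries methyl in place of hydrogen on an oxygen on an aromatic ring, hydroxy to methoxy: methyl in place of hydrogen on an oxygen on an aromatic ring. Among the compounds with values here, no measured step gauges this change, so no step beyond the scatter is expected in this assay, and another limit is likely. The estimated a number no higher from compound 2 to compound 3 (the limit leaves the size open) is correspondingly small. Compound 3 is expected at 50000 nM, within an estimated range of 25000 nM to 100000 nM.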

Compound 3, half-maximal inhibitory concentration: > 50000 nM
Compound 3 gave a limit, no number; the forecaster's own chance of this, stated with the estimate: 85%; the middle value lies on the limit itself.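

No step to compound 3 from compound 1 or compound 2 can be read, as all three values are limits: the limit of > 50000 nM in this assay, at which 3 of the 3 values shown sit.

As far as these compounds go, whether either of these two structural changes alters the cytotoxicity at all remains open.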